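The source may report more compounds than this note shows. Statements on the series, on what has been measured and on what is new or still open speak of the compounds shown alone.

Compound 1 `CCCCCNC(=O)n1c(=O)oc2cc(-c3ccc(F)cc3)ccc21` and compound 2 `CCOCCNC(=O)n1c(=O)oc2cc(-c3ccc(F)cc3)ccc21` share one core and differ only in the chain that hangs from the amide-type nitrogen. In an assay on HEK293 cells for inhibition of acid ceramidase (Homo sapiens), read by fluorescence, with stated times of 10 min and 3 h (a lower number here means a stronger inhibitor, a higher number a weaker inhibitor), compound 1 gives 60 nM, whereas compound 2 gives 2300 nM. Within the data shown here, replacing the propyl end of that chain with an ethoxy end brought a 38-fold higher number from compound 1 to compound 2 (1.58 log units; beyond the scatter), so compound 2 stands as the higher, and therefore weaker, of the two numbers measured so far.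

Compound 3 `COCCCNC(=O)n1c(=O)oc2cc(-c3ccc(F)cc3)ccc21` is built from exactly the same atoms as compound 2, joined differently: methoxymethyl in place of ethoxy on a saturated chain carbon, two bonds along the chain from an amide-type nitrogen. The oxygen of the chain thus sits one bond further out from the nitrogen, while the chain keeps its length. Among the measured compounds shown here, no measured pair shows the effect of shifting the oxygen in this way; the one step on record concerns introducing the oxygen, not moving it. With the oxygen still present, a large recovery toward compound 1 seems unlikely, and the expected step is a 1.8-fold lower number from compound 2 to compound 3 (0.25 log units; within the scatter), a modest move at the edge of the scatter. Compound 3 is therefore expected to give about 1300 nM in this assay, estimated between 400 nM and 4500 nM.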

Compound 3, half-maximal inhibitory concentration: 2600 nM
Compound 3: the middle estimate sits 2.0-fold (0.30 log units) below what was measured, and the stated range covers the measured number.
By their numbers in this assay, from the lowest: compound 1; then compounds 2 and 3 (each within the scatter of the next).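

In this assay, methoxymethyl in place of ethoxy on a saturated chain carbon, two bonds along the chain from an amide-type nitrogen, gives a 1.1-fold higher number from compound 2 to compound 3 (0.05 log units; within the scatter) and so leaves compound 2 and compound 3 indistinguishable; for these two chains, where the oxygen sits makes no difference that the numbers can show. Measured against the all-carbon chain, methoxy in place of ethyl on a saturated chain carbon, three bonds along the chain from an amide-type nitrogen, brings a 43-fold higher number from compound 1 to compound 3 (1.64 log units; beyond the scatter) in the same direction as a 38-fold higher number from compound 1 to compound 2 (1.58 log units; beyond the scatter) did. The large gap to compound 1 therefore appears with the oxygen in either of these two placings, and it was not tied to the single chain seen before.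

The compounds shown leave open whether a terminal hydroxyl, an amine in place of the chain oxygen or a longer all-carbon chain would come close to compound 1 at 60 nM or stay with the two oxygen chains. Nothing measured here gives a reason for the gap between the all-carbon chain and the oxygen chains.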